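Pyrrolidin-1-yl for ethylamino on the side chain

The source may report more compounds than this note shows. Statements on the series, on what has been measured and on what is new or still open speak of the compounds shown alone.

compound 1 `C/C=C(/C)C(=O)OC(C)c1cc2c(cc1OC)OC(C)(C)C=C2`: 139000 nM
compound 2 `COc1cc2c(cc1C(C)NCCCc1ccccc1)C=CC(C)(C)O2`: 1080 nM
compound 3 `CCNC(C)c1cc2c(cc1OC)OC(C)(C)C=C2`: 176000 nM

All three values come from an ADME assay on L6 cells (Rattus norvegicus) for cytotoxicity; on this read-out lower numbers stand for stronger inhibition and higher numbers for weaker inhibition. Compound 3 shares the upper part of the range with compound 1, and the two are not separated by the measurements. Compound 2 lies far lower.

The next member is compound 4 `COc1cc2c(cc1C(C)N1CCCC1)C=CC(C)(C)O2`, which has pyrrolidin-1-yl in place of ethylamino on a saturated chain carbon bound to an aromatic carbon and a saturated chain carbon.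

Among the compounds with values here, two measured steps bear on this change. Exchange at this same carbon has so far moved little: a 1.3-fold higher number from compound 1 to compound 3 (0.10 log units; within the scatter). Within the data shown here, the only large step is a 160-fold higher number from compound 2 to compound 3 (2.21 log units; beyond the scatter), and it turns on a benzyl group that compound 4 does not carry. Among the measured compounds shown here, no measured compound has a ring on this nitrogen, so the evidence is indirect. In this assay, no step beyond the scatter is expected, and any drift is more likely towards a slightly lower number than a higher one. The estimated step is a 1.5-fold lower number from compound 3 to compound 4 (0.17 log units; within the scatter). For compound 4 the expected value is 120000 nM, with an estimated range of 45000 nM to 250000 nM.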

Compound 4, half-maximal inhibitory concentration: 177000 nM
Compound 4: middle estimate off by 1.5-fold (0.17 log units), on the low side; the measured number falls inside the stated range.
By their numbers in this assay, from the lowest: compound 2; then compounds 1, 3 and 4 (each within the scatter of the next).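

In this assay, the change to a ring on this nitrogen gives a 1.0-fold higher number from compound 3 to compound 4 (0.00 log units; within the scatter): pyrrolidin-1-yl brings a five-membered non-aromatic ring and no hydrogen-bond donor, yet the read-out does not separate it from ethylamino. With a 1.3-fold higher number from compound 1 to compound 4 (0.10 log units; within the scatter), ((1-methylprop-1-en-1-yl)carbonyl)oxy, ethylamino and pyrrolidin-1-yl now stand as three groups on this saturated chain carbon whose values lie within the scatter of one another, so among compounds 1, 3 and 4 the exchange of this group has produced no measurable difference. Nothing available explains why these values stay together.

Still open, on these data alone, is whether a phenyl group on the pyrrolidine ring, or a 3-phenylpropyl group on the nitrogen of a tertiary amine, would bring the number towards that of compound 2 at 1080 nM. Also open, as far as these compounds go, is whether other rings at this carbon, such as piperidin-1-yl or morpholin-4-yl, or a carboxylic acid on the side chain, would stay with compounds 1, 3 and 4 or move away from them.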